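This account rests on a few compounds, and the source may have more. Where it says the series, first, only, none or still open, it means among the compounds named here.

Compound 1 `Cc1ccc(NC(=O)C(=O)Nc2ccc(OCC(=O)O)c(F)c2)cc1`: 11.4%
Compound 2 `CC(C)(Oc1ccccc1)C(=O)Nc1ccc(OCC(=O)O)c(F)c1`: 3.56%
Compound 3 `CC(Oc1ccccc1F)C(=O)Nc1ccc(OCC(=O)O)c(F)c1`: 35.1%

In a functional assay on CHO cells for agonist activity at Free fatty acid receptor 1 (Homo sapiens), read by FLIPR, tested at 100 nM (a lower number here means a weaker effect, a higher number a stronger effect of the compound at the concentration tested), compound 3 gives the highest of the three numbers. Its nearest neighbour is compound 1, whose value lies lower by more than the usual scatter, and the furthest is compound 2, lower still and also beyond the scatter. Compound 4 `Cc1ccc(OC(C)C(=O)Nc2ccc(OCC(=O)O)c(F)c2)cc1C` has not yet been measured. It differs from compound 3 in one place: 3,4-dimethylphenyl in place of 2-fluorophenyl on an oxygen on a saturated carbon. Within the data shown here, no single step between measured compounds is available to anchor this change, so the expectation rests on compound 3 alone. The step from compound 3 to compound 4 is expected to be a number 4.9 percentage points higher from compound 3 to compound 4 (within the scatter), a small rise that may not exceed the scatter. Compound 4 is therefore estimated at 40%, within a range from 15% to 70%.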

Compound 4, a percentage reported as activity, at one concentration (the size of the read-out at that concentration, not a potency): 36.8%
Compound 4: middle estimate off by 3.2 percentage points, on the high side, within the range that was stated.
By their numbers in this assay, from the lowest: compounds 2 and 1 (each within the scatter of the next); then compounds 3 and 4 (each within the scatter of the next).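

In this assay, 3,4-dimethylphenyl in place of 2-fluorophenyl on an oxygen on a saturated carbon gives a number 1.7 percentage points higher from compound 3 to compound 4 (within the scatter). This position therefore accepts two differently substituted phenyl groups, one bearing fluorine and one bearing two methyl groups, with no difference beyond the scatter. Nothing available explains why the two groups read alike. The compounds shown leave open how a phenyl group carrying an amine or a carboxylic acid would read at this position. They also leave open the effect of a longer chain on the oxygen.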